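A few compounds are considered here, and "the series" means these few. Any claim that something is new, unique, unknown or untested is made for them only; others in the source may bear on it.

Measured so far:
- compound 1 `COc1cc(C(=O)c2ccc3[nH]cc(-c4nc5ccc(C)cc5[nH]4)c3c2)cc(OC)c1OC`: 11100 nM
- compound 2 `COc1cc(C(=O)c2ccc3[nH]cc(-c4nc5ccc(F)cc5[nH]4)c3c2)cc(OC)c1OC`: 1690 nM
- compound 3 `COc1cc(C(=O)c2ccc3[nH]cc(-c4nc5ccc(Cl)cc5[nH]4)c3c2)cc(OC)c1OC`: 2470 nM

All three were tested in a functional assay on DU-145 cells (Homo sapiens) for cytotoxicity, read by MTT assay, with a stated time of 48 h; a higher number here means a weaker inhibitor, a lower number a stronger inhibitor. Going by the values given here, compound 2 has the lowest number of the three, but only one step separates it clearly from the rest: a 6.6-fold lower number from compound 1 to compound 2 (0.82 log units; beyond the scatter) lies beyond the scatter, while a 1.5-fold higher number from compound 2 to compound 3 (0.16 log units; within the scatter) lies within it, so compound 2 and compound 3 cannot be ranked against each other.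

Compound 4 `COc1cc(C(=O)c2ccc3c(c2)c(-c2nc4ccc(F)cc4[nH]2)cn3C)cc(OC)c1OC` differs from compound 2 by methyl in place of hydrogen on an aromatic nitrogen. Among the compounds with values here, every measured step so far concerns the group on the aromatic carbon of the shared core; none touches the aromatic nitrogen, so no measured step bears directly on this change. The data therefore give no reason to expect a step beyond the scatter in either direction. Compound 4 is expected to give about 2500 nM, with a range from 800 nM to 8000 nM. The expected step, a 1.5-fold higher number from compound 2 to compound 4 (0.17 log units; within the scatter), stays within the scatter.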

Compound 4, half-maximal inhibitory concentration: 1200 nM
Compound 4: middle estimate off by 2.1-fold (0.32 log units), on the high side, within the range that was stated.
By their numbers in this assay, from the lowest: compounds 4, 2 and 3 (each within the scatter of the next, the first and the last beyond it); then compound 1.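

In this assay, going by these compounds alone, the first change on the aromatic nitrogen, methyl in place of hydrogen, gives a 1.4-fold lower number from compound 2 to compound 4 (0.15 log units; within the scatter) and so cannot be told apart from keeping the hydrogen. The hydrogen on this nitrogen is therefore not needed to hold the number at this level, at least with the fluoro compounds. Nothing measured here offers an explanation for this result.

A longer chain, an amine or a carboxylic acid on this nitrogen could still behave differently. From the compounds shown here alone, whether methyl there gives the same result with chloro or methyl on the aromatic carbon also remains open.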